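Aryl swap on a triazole amide, both anchors inactive

The source may report more compounds than this note shows. Statements on the series, on what has been measured and on what is new or still open speak of the compounds shown alone.

Compound 1, `CC(C)n1ncc2c(C(=O)Nc3cccnc3)cccc21`: in a functional assay on MGC-803 cells (Homo sapiens) for inhibition, read by MTT assay, with a stated time of 72 h (on this read-out lower numbers stand for stronger inhibition and higher numbers for weaker inhibition), compound 1 gives > 40000 nM, a limit of the assay and not a number.
Compound 2, `CC(C)n1ncc2c(C(=O)NCc3cn(-c4ccc(I)cc4)nn3)cccc21`: in this assay compound 2 gives > 40000 nM, likewise a limit of the assay.

Compound 2 therefore stands at the limit rather than at a number, and the limit of > 40000 nM in this assay, at which 2 of the 2 values shown sit, describes every value shown. Compound 3, `CC(C)n1ncc2c(C(=O)NCc3cn(-c4ccccc4F)nn3)cccc21`, differs from compound 2 by 2-fluorophenyl in place of 4-iodophenyl on an aromatic nitrogen. Within the data shown here, no step between measured compounds exists, so no measured step gives a scale for this change. The expectation for compound 3 rests on compound 2 sitting at > 40000 nM, a limit. Compound 3 is expected to give about 50000 nM in this assay, within 20000 nM to 150000 nM, most probably reported again only as a limit. That estimate means a step that the limit leaves unreadable from compound 2 to compound 3 in this assay, expected to be none beyond the scatter.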

Compound 3, half-maximal inhibitory concentration: > 40000 nM
Compound 3 ended at the assay's limit; the forecaster's own chance of this, stated with the estimate: 80%; the middle value lies beyond the limit too.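

Among these compounds, compound 2 and compound 3 both sit at a limit in this assay, not at a number, and no step between them can be read. The compounds shown leave open whether 2-fluorophenyl and 4-iodophenyl differ at all, and what change to the shared core would give a measurable value.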